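The compounds below may be only part of what the source reports. "The series", "measured", "known", "first", "only" and "open" are said of these compounds alone.

Measured so far:
Compound 1 `Cc1nn(C(C)(C)C)c2nc(C3CC3)c(/C=C/[C@@H](O)C[C@@H](O)CC(=O)O)c(-c3ccc(F)cc3)c12` gives 4.5% in an in vivo functional assay on the whole organism for inhibition of 3-hydroxy-3-methylglutaryl-coenzyme A reductase (Rattus norvegicus), at a dose of 0.2 mg/kg by the oral route; on this read-out higher numbers stand for a stronger effect at the one dose given and lower numbers for a weaker effect.
Compound 2 `Cc1nn(-c2ccccc2)c2nc(C(C)C)c(/C=C/[C@@H](O)C[C@@H](O)CC(=O)O)c(-c3ccc(F)cc3)c12` gives 3.3% in this assay.
Compound 3 `COc1ccc(-n2nc(C)c3c(-c4ccc(F)cc4)c(/C=C/[C@@H](O)C[C@@H](O)CC(=O)O)c(C(C)C)nc32)cc1` gives -27.5% in this assay.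

Compound 3 stands lowest of the three, beyond the scatter from both compound 2 and compound 1. Compound 4 `Cc1nn(C(C)(C)C)c2nc(C(C)C)c(/C=C/[C@@H](O)C[C@@H](O)CC(=O)O)c(-c3ccc(F)cc3)c12` differs from it by tert-butyl in place of 4-methoxyphenyl on an aromatic nitrogen. For the measured compounds named here, one measured step bears on this: a number 30.8 percentage points lower from compound 2 to compound 3 (beyond the scatter), and compound 4 reverses that methoxy and in addition exchanges the phenyl for tert-butyl. Compound 1, which carries tert-butyl on the same nitrogen, and compound 2 show values within the scatter of each other, so the tert-butyl itself is not expected to move the read-out far. Compound 4 is therefore expected to rise by a number 31.5 percentage points higher from compound 3 to compound 4 (beyond the scatter). That expected rise would bring it back into the range of compounds 1 and 2. For compound 4 the estimate is 4% (range -12% to 20%).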

Compound 4, a percentage reported as inhibition, in the whole organism at one dose (the size of the read-out at that dose, not a potency): 51.8%
Beside the measured number, compound 4's estimate is 47.8 percentage points below it; the measured number lies above the stated range.
By their numbers in this assay, from the lowest: compound 3; then compounds 2 and 1 (each within the scatter of the next); then compound 4.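

In this assay tert-butyl in place of 4-methoxyphenyl on the aromatic nitrogen gives a number 79.3 percentage points higher from compound 3 to compound 4 (beyond the scatter) and tert-butyl in place of phenyl gives a number 48.5 percentage points higher from compound 2 to compound 4 (beyond the scatter) and so shows that this nitrogen tolerates a group with no ring and can carry a large gain. The aromatic carbon counts as well: isopropyl in place of cyclopropyl there gives a number 47.3 percentage points higher from compound 1 to compound 4 (beyond the scatter) with tert-butyl kept on the nitrogen. Nothing in the data gives a reason for these steps.

Still open, going by these compounds, is whether methyl, ethyl or cyclohexyl on that nitrogen would hold the read-out. Also open, on these data alone, is whether a propyl chain on the aromatic carbon would do the same.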